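A few compounds are considered here, and "the series" means these few. Any claim that something is new, unique, unknown or untested is made for them only; others in the source may bear on it.

Among the compounds with values here, compound 1 `NC(=O)CC[C@H](NC(=O)CN(c1ncnc2c1ncn2C1CCCCO1)C1CC1)C(=O)OCc1ccccc1` is one of three compounds measured in a functional assay on the whole organism (Tail, strain ICR) with Mus musculus as the target, in the tail flick test, with a stated time of 120 min, at a dose of 25 umol/kg by the oral route (on this read-out higher numbers stand for a stronger effect at the one dose given and lower numbers for a weaker effect), where compound 1 gives 22.3%. Its number is the lowest of the three, but compound 3 `CC(C)[C@H](NC(=O)CN(c1nc(Cl)nc2[nH]cnc12)C1CC1)C(=O)OCc1ccccc1` at 27.3% lies within the scatter of it, while compound 2 `C[C@H](NC(=O)CN(c1nc(Cl)nc2[nH]cnc12)C1CC1)C(=O)OCc1ccccc1` at 36.1% stands beyond it. Compound 4 `C[C@@H](O)[C@H](NC(=O)CN(c1ncnc2c1ncn2C1CCCCO1)C1CC1)C(=O)OCc1ccccc1` differs from compound 1 by 1-hydroxyethyl in place of 2-carbamoylethyl on a saturated chain carbon bound to an amide-type nitrogen and a carbonyl carbon. Within the data shown here, the only measured step at that place is the change of side chain size in a number 8.8 percentage points lower from compound 2 to compound 3 (within the scatter), which stayed within the scatter. On that basis the shortening of the side chain in compound 4 is expected to shift the read-out little, so a step of a number 5.7 percentage points higher from compound 1 to compound 4 (within the scatter) is estimated. Compound 4 is therefore expected to give about 28%, within a range from 15% to 42%.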

Compound 4, a percentage reported as activity, at one dose (the size of the read-out at that dose, not a potency): 10.9%
Estimate against measurement, compound 4: 17.1 percentage points above, and the stated range ends above it.
By their numbers in this assay, from the lowest: compound 4; then compounds 1, 3 and 2 (each within the scatter of the next, the first and the last beyond it).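

At this position, on a saturated chain carbon bound to an amide-type nitrogen and a carbonyl carbon, this assay now shows a change of side chain that leaves the scatter: 1-hydroxyethyl in place of 2-carbamoylethyl gives a number 11.4 percentage points lower from compound 1 to compound 4 (beyond the scatter), whereas a number 8.8 percentage points lower from compound 2 to compound 3 (within the scatter) did not. The two groups have the same count of hydrogen-bond donors and acceptors, but the entering group has fewer heavy atoms and a defined stereocentre, and this one step cannot separate those differences. Nothing given here bears on the reason for the step.

On these data alone, whether an amine, a carboxylic acid or a longer chain at this position would raise or lower the number remains open. So does whether the same change would give a similar step on the core of compound 2.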